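Solubility Outlook for a Dichloropyridinyl Amide

A few compounds are considered here, and "the series" means these few. Any claim that something is new, unique, unknown or untested is made for them only; others in the source may bear on it.

Among the measured compounds shown here, compound 2 `CC(Cl)C(=O)Nc1cccc(-c2nc3ccccc3s2)c1` gives 830 nM in a physicochemical assay for solubility, in phosphate buffer, measured as kinetic solubility, with a stated time of 18 h, at pH 7.4 (on this read-out lower numbers stand for lower solubility and higher numbers for higher solubility), the lowest of the two numbers known so far, while compound 1 `O=C(O)/C=C/C(=O)Nc1cccc(-c2nc3ccccc3s2)c1` gives 56000 nM in this assay. For the measured compounds named here, the only measured step, a 67-fold lower number from compound 1 to compound 2 (1.83 log units; beyond the scatter), concerned the exchange of 2-carboxyethenyl for 1-chloroethyl and does not directly bear on the present change. Compound 3 `O=C(Nc1cccc(-c2nc3ccccc3s2)c1)c1ccc(Cl)nc1Cl` differs from compound 2 by 2,6-dichloropyridin-3-yl in place of 1-chloroethyl on a carbonyl carbon. Without a measured step on this kind of change, the size is uncertain, but a lower number is expected. Compound 3 is therefore estimated at 300 nM, within 50 nM to 2500 nM. The expected step is a 2.8-fold lower number from compound 2 to compound 3 (0.44 log units; beyond the scatter).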

Compound 3, solubility: 350 nM
Estimate against measurement, compound 3: 1.2-fold (0.07 log units) below, within the range that was stated.
By their numbers in this assay, from the lowest: compound 3; then compound 2; then compound 1.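

Among the compounds shown here, with 2,6-dichloropyridin-3-yl, a six-membered aromatic ring now stands on this carbonyl carbon for the first time, and this assay shows a 2.4-fold lower number from compound 2 to compound 3 (0.38 log units; beyond the scatter) in a modest step. Measured against 2-carboxyethenyl, the same group gives a 160-fold lower number from compound 1 to compound 3 (2.20 log units; beyond the scatter) as a large step, which leaves compound 3 lowest and compound 1 highest of the three. No available evidence accounts for either step. The compounds shown leave open how an amine or a carboxylic acid in place of 2,6-dichloropyridin-3-yl would read, and what the pyridine ring would give without its two chlorines.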